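The source may report more compounds than this note shows. Statements on the series, on what has been measured and on what is new or still open speak of the compounds shown alone.

Three compounds built on one shared core come into view here. Compound 1 `CCCC[C@H](NC(=O)[C@H](CCCCN)NC(=O)[C@H](CCCNC(=N)N)NC(=O)c1ccccc1)C(N)=O` was tested in an ADME assay for permeability, using PAMPA (on this read-out lower numbers stand for lower permeability and higher numbers for higher permeability), and gave no number at all; it was reported only as "impermeable" (no number reported). Compound 2 `CCCC[C@H](NC(=O)[C@H](CCCCN)NC(=O)[C@H](CCCNC(=N)N)NC(=O)c1ccc(/C=C2\SC(=O)N(c3ccc(C)cc3)C2=O)cc1)C(N)=O`, which carries a much larger group at the same end of the molecule, gave a measured value in this assay of 0.66 10^-6 cm/s. So compound 1 stands without a single figure to place it, and the only numbered result belongs to compound 2.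

Compound 3 `CCCC[C@H](NC(=O)[C@H](CCCCN)NC(=O)[C@H](CCCNC(=N)N)NC(=O)c1cccs1)C(N)=O` is the next structure to be measured in this assay. It differs from compound 1 in one place: thiophen-2-yl in place of phenyl on a carbonyl carbon. Since no measured step between any two of these compounds is available, the size of the change from compound 1 to compound 3 cannot be drawn from the data; a small step is expected, within the usual scatter, in either direction. Compound 3 is expected to come out at 0.1 10^-6 cm/s, between 0.02 10^-6 cm/s and 0.5 10^-6 cm/s, with a real chance of a limit rather than a number.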

Compound 3, apparent permeability: "impermeable" (no number reported)
For compound 3 the study gives words and no number; the estimate stays without a comparison.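

In this assay, within the data shown here, compound 1 and compound 3 are both reported in words only, so no step between them can be read. From the compounds shown here alone, whether thiophen-2-yl in place of phenyl shifts this read-out at all stays open. No supporting data bear on this result.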